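This account rests on a few compounds, and the source may have more. Where it says the series, first, only, none or still open, it means among the compounds named here.

In a physicochemical assay for solubility (on this read-out lower numbers stand for lower solubility and higher numbers for higher solubility), compound 1 `C[C@@H]1CN(c2c(C#N)c(C(F)F)nn2-c2ccc(S(C)(=O)=O)cc2)[C@H](C)CO1` gives 50 ug/mL and compound 2 `CC1CCCN(c2c(C#N)c(C(F)F)nn2-c2ccc(S(C)(=O)=O)cc2)C1` gives 50 ug/mL. Between these two, the data show no change at the digits printed from compound 1 to compound 2 (within the scatter).

Compound 3 `CS(=O)(=O)c1ccc(-n2nc(C(F)F)c(C#N)c2NCC2CC2)cc1` gives > 200 ug/mL, which is a limit of the assay and not a number. Compound 3 therefore stands at the limit of > 200 ug/mL in this assay, at which 1 of the 3 values shown sits.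

Compound 4 `CS(=O)(=O)c1ccc(-n2nc(C(F)F)c(C#N)c2NC2CCCC2)cc1` has not yet been measured. It has cyclopentyl in place of cyclopropylmethyl on a nitrogen on an aromatic ring.

Among the compounds with values here, no measured step makes this exact swap, so the guidance is indirect. The closest steps are an at least 4.0-fold higher number from compound 2 to compound 3 (0.60 log units; beyond the scatter) and an at least 4.0-fold higher number from compound 1 to compound 3 (0.60 log units; beyond the scatter). In both, a ring joined through its own nitrogen gives way to the (cyclopropylmethyl)amino group. On these data alone, compound 4 keeps an amino link, as a cyclopentylamino group, so it should stay nearer compound 3 than compound 1 or compound 2, though the new group is untested.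

The expected result in this assay is a modest drop, an at least 1.6-fold lower number from compound 3 to compound 4 (0.22 log units; that floor lies within the scatter). For compound 4 the estimated solubility is 120 ug/mL, with an expected range from 50 ug/mL to 220 ug/mL.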

Compound 4, solubility: 100 ug/mL
Compound 4: the middle estimate sits 1.2-fold (0.08 log units) above what was measured, and the stated range covers the measured number.
By their numbers in this assay, from the lowest: compounds 1, 2 and 4 (each within the scatter of the next). At a limit, above all of these: compound 3.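

In this assay, changing the group on the nitrogen from cyclopropylmethyl to cyclopentyl gives an at least 2.0-fold lower number from compound 3 to compound 4 (0.30 log units; that floor lies within the scatter), so this change cannot be told apart from repeat-measurement noise on the floor alone. Compound 3 stands at a limit of the assay and not at a number: the limit of > 200 ug/mL in this assay, at which 1 of the 4 values shown sits.

Against the two compounds with a ring joined through its own nitrogen, the readings are a 2.0-fold higher number from compound 2 to compound 4 (0.30 log units; within the scatter) and a 2.0-fold higher number from compound 1 to compound 4 (0.30 log units; within the scatter), so, unlike compound 3, compound 4 is not separated from them, and the amino link alone does not set a compound apart.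

On these data alone, how far compound 3 truly lies from compound 4 stays open. So does how an open chain such as n-butyl, or a cyclopentyl ring carrying a hydroxyl group, would read on that nitrogen in this assay.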